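Fluoro to trifluoromethyl, repeated on a second core

The source may hold more compounds than are shown below. What is called first, only, known or untested is meant among the compounds shown, and "the series" means these compounds.

Measured so far:
compound 1 `Cc1ccc(-c2nn(-c3ccccc3)cc2-c2nc3ccccc3n2S(=O)(=O)c2ccc(F)cc2)cc1` — 3670 nM
compound 2 `Cc1ccc(-c2nn(-c3ccccc3)cc2-c2nc3ccccc3n2S(=O)(=O)c2ccc(C(F)(F)F)cc2)cc1` — 1520 nM
compound 3 `O=S(=O)(c1ccccc1)n1c(-c2cn(-c3ccccc3)nc2-c2ccc(F)cc2)nc2ccccc21` — 680 nM

Compound 1 and compound 2 share one core, compound 3 a different one; the difference between the two cores is not broken down here. In a functional assay on HeLa cells (Homo sapiens) for antiproliferative activity, read by MTT assay, with a stated time of 24 h (a lower number here means a stronger inhibitor, a higher number a weaker inhibitor), compound 1 gives 3670 nM and compound 2 gives 1520 nM; the change trifluoromethyl in place of fluoro on an aromatic carbon made a 2.4-fold lower number from compound 1 to compound 2 (0.38 log units; beyond the scatter). In this assay compound 3 gives 680 nM, the lowest of the three numbers, its steps to compound 2 and compound 1 both beyond the scatter.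

Compound 4 `O=S(=O)(c1ccccc1)n1c(-c2cn(-c3ccccc3)nc2-c2ccc(C(F)(F)F)cc2)nc2ccccc21` is not yet measured in this assay. It carries the same change relative to compound 3, (trifluoromethyl in place of fluoro on an aromatic carbon); the place reads the same as between compound 1 and compound 2, so this is the same change on the other core.

For the measured compounds named here, compound 4 is expected to show a 2.3-fold lower number from compound 3 to compound 4 (0.36 log units; beyond the scatter) because a 2.4-fold lower number from compound 1 to compound 2 (0.38 log units; beyond the scatter) is the only earlier instance of this change and the step to apply. Compound 4 is therefore estimated at 300 nM in this assay. Going by the values given here, for compound 4 the expected range runs from 130 nM to 700 nM, wide because a 2.4-fold lower number from compound 1 to compound 2 (0.38 log units; beyond the scatter) is the single prior step that carries it.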

Compound 4, half-maximal inhibitory concentration: 560 nM
The estimate for compound 4 lay 1.9-fold (0.27 log units) below the measured number, and the stated range covers the measured number.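

In this assay, trifluoromethyl in place of fluoro on the second core gives a 1.2-fold lower number from compound 3 to compound 4 (0.08 log units; within the scatter), so on this core the change cannot be told apart from repeat-measurement noise. Set beside the step on the first core, it does not differ beyond what such pairs of steps allow: the same change on two cores in this assay, a 2.4-fold lower number (0.38 log units; beyond the scatter) from compound 1 to compound 2 and a 1.2-fold lower number (0.08 log units; within the scatter) from compound 3 to compound 4, 2.0-fold (0.30 log units) apart, within the scatter of two such steps. The data are therefore compatible with the change carrying across the two cores without a detectable dependence on core, but they show neither that the step has the same size on both nor that it brings a real gain on the second core, and a single pair on each core supports no general rule for the series.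

The compounds shown leave open how a chloro, a methoxy, a nitrile, an amine or a carboxylic acid would read at this same aromatic carbon on either core. They also leave open whether the comparison would hold on further cores or in other cell lines.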